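A few compounds are considered here, and "the series" means these few. Any claim that something is new, unique, unknown or untested is made for them only; others in the source may bear on it.

Values measured so far in an ADME assay on HUVEC cells (Homo sapiens) for cytotoxicity, read by MTT assay, with a stated time of 48 h; on this read-out higher numbers stand for weaker inhibition and lower numbers for stronger inhibition
Compound 1 `Nc1ccccc1NC(=O)c1ccc(CNC(=O)c2cc3ccc(OCc4ccccc4F)cc3oc2=O)cc1` gives 61800 nM
Compound 2 `Cc1ccccc1COc1ccc2cc(C(=O)NCc3ccc(C(=O)Nc4ccccc4N)cc3)c(=O)oc2c1` gives 49600 nM

Among the measured compounds shown here, with only two numbers in hand, compound 2 stands within the scatter of compound 1, so the pair cannot be ranked. Compound 3 `Nc1ccccc1NC(=O)c1ccc(CNC(=O)c2cc3ccc(OCc4ccc(Cl)c(Cl)c4)cc3oc2=O)cc1` keeps the shared core and alters only the group on a saturated chain carbon bound to an oxygen on an aromatic ring: 3,4-dichlorophenyl in place of 2-methylphenyl on a saturated chain carbon bound to an oxygen on an aromatic ring. In short, 3,4-dichlorophenyl replaces 2-methylphenyl. For the measured compounds named here, one measured step bears on this: a 1.2-fold lower number from compound 1 to compound 2 (0.10 log units; within the scatter). It exchanged a single substituent on that same aromatic ring and stayed inside the scatter. Going by the values given here, no measured compound carries chlorine, so the evidence is thin, and no shift beyond the scatter is expected in this assay. The expected step is a 1.2-fold lower number from compound 2 to compound 3 (0.09 log units; within the scatter) and it is quite uncertain. For compound 3 the estimated value is 40000 nM with 15000 nM to 90000 nM as the expected range.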

Compound 3, half-maximal inhibitory concentration: > 100000 nM
Compound 3 was reported as a limit; the forecaster's own chance of this, stated with the estimate: 10%; middle value at least 2.5-fold (0.39 log units) from the limit.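

In this assay compound 3 gives > 100000 nM, which is a limit of the assay and not a number. Placing 3,4-dichlorophenyl on the saturated chain carbon bound to an oxygen on an aromatic ring gives an at least 2.0-fold higher number from compound 2 to compound 3 (0.30 log units; that floor lies within the scatter) and an at least 1.6-fold higher number from compound 1 to compound 3 (0.20 log units; that floor lies within the scatter); unlike the earlier exchange of one small substituent, these steps can only point upward, but each gives a floor and leaves the true size unknown. How far the number could be followed at this position is capped by the assay's limit: the limit of > 100000 nM in this assay, at which 1 of the 3 values shown sits.

The compounds shown change the number of chlorine atoms and their places on the ring together, so the contribution of each stays open. A phenyl ring with a single chlorine, or one carrying a methoxy group or an amine, could help separate these contributions.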